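This account rests on a few compounds, and the source may have more. Where it says the series, first, only, none or still open, it means among the compounds named here.

Compound 1, whose structure is `COc1ccc(CN(C(=O)C=C(C)C)c2cc(OC)c(OC)c(OC)c2)cc1O`, stands lowest of the two measured numbers in a functional assay on MGC-803 cells (Homo sapiens) for inhibition, read by MTT assay, with a stated time of 48 h; on this read-out lower numbers stand for stronger inhibition and higher numbers for weaker inhibition: compound 1 gives 320 nM in this assay. Within the data shown here, the only other measured compound is compound 2, with structure `COc1ccc(CNc2cc(OC)c(OC)c(OC)c2)cc1N`, and in this assay compound 2 gives 7970 nM, a much weaker figure that lies well beyond the scatter from compound 1. Among the measured compounds shown here, no single-point step between measured compounds connects them, so compound 2 serves only as a point of reference.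

The compound to be measured is compound 3, with structure `COc1ccc(CN(C(=O)CBr)c2cc(OC)c(OC)c(OC)c2)cc1O`. It differs from compound 1 in one place: bromomethyl in place of 2-methylprop-1-en-1-yl on a carbonyl carbon, on a carbonyl carbon whose other neighbour is an amide-type nitrogen.

For this step nothing comparable has been measured. The estimate is that the change from compound 1 to compound 3 stays within the scatter, with a slight lean toward a lower number, as a 1.3-fold lower number from compound 1 to compound 3 (0.11 log units; within the scatter). Compound 3 is therefore expected to give 250 nM in this assay, with a range from 60 nM to 1500 nM.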

Compound 3, half-maximal inhibitory concentration: 140 nM
For compound 3 the middle estimate is 1.8-fold (0.25 log units) above the measured one, within the range that was stated.
By their numbers in this assay, from the lowest: compound 3; then compound 1; then compound 2.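

In this assay, putting bromomethyl in place of 2-methylprop-1-en-1-yl on the carbonyl carbon gives a 2.3-fold lower number from compound 1 to compound 3 (0.36 log units; beyond the scatter), a modest step and the first that can be read at this position. It shows that the number in this assay does not depend on keeping the 2-methylprop-1-en-1-yl group: the double bond outside aromatic rings leaves, a bromine enters, the heavy atom count of the group falls from 4 to 2, and the number still moves downward. Nothing available explains this step, so the shift cannot be assigned to any one of these differences.

The compounds shown leave open whether the bromine or the shorter group matters, a question that chloromethyl, plain methyl or a longer chain such as 3-bromopropyl on the same carbonyl carbon would address. They also leave open how far this position accepts other kinds of group, such as an aminomethyl group or a carboxylic acid, and whether the step from compound 1 to compound 3 holds on cells other than those of this single assay.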